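The source may report more compounds than this note shows. Statements on the series, on what has been measured and on what is new or still open speak of the compounds shown alone.

Measured compounds in a physicochemical assay for solubility, read by HPLC, using the shake flask method, measured as kinetic solubility, with a stated time of 2 h, at pH 7.4; a higher number here means a more soluble compound, a lower number a less soluble compound:
- compound 1 `Cc1cc(NCc2ccccn2)n2ncc(-c3ccccc3F)c2n1`: 5000 nM
- compound 2 `Cc1cc(NCc2ccccn2)n2ncc(-c3ccco3)c2n1`: 48800 nM

Among the compounds with values here, compound 2 holds the higher of the two numbers in this assay; its only neighbour is compound 1, and the step of a 9.8-fold higher number from compound 1 to compound 2 (0.99 log units; beyond the scatter) is the one aryl swap on the shared core measured so far.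

Compound 3 `Cc1cc(NCc2ccccn2)n2ncc(-c3ccc(O)cc3)c2n1` differs from compound 2 by 4-hydroxyphenyl in place of furan-2-yl on an aromatic carbon. Within the data shown here, no measured step covers this exact exchange; the one that bears on it is a 9.8-fold higher number from compound 1 to compound 2 (0.99 log units; beyond the scatter), which shows that swapping the aryl group at this position moves the number by a modest amount. A six-membered carbon ring returns, as in compound 1, but with a hydrogen-bond donor added, so the outcome is uncertain in direction. A modest step is expected, more likely downward than upward, and the expected step is a 1.6-fold lower number from compound 2 to compound 3 (0.21 log units; within the scatter). Compound 3 is therefore estimated at 30000 nM, with a range from 8000 nM to 100000 nM.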

Compound 3, solubility: 10900 nM
Compound 3: the middle estimate sits 2.8-fold (0.44 log units) above what was measured; measured number inside the range.
By their numbers in this assay, from the lowest: compound 1; then compound 3; then compound 2.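

In this assay, this aromatic carbon on the shared core now has three groups compared, and the furan-2-yl group keeps the highest number: a 4.5-fold lower number from compound 2 to compound 3 (0.65 log units; beyond the scatter) when 4-hydroxyphenyl takes its place. The two six-membered carbon rings also separate, since a 2.2-fold higher number from compound 1 to compound 3 (0.34 log units; beyond the scatter) when 4-hydroxyphenyl replaces 2-fluorophenyl. The read-out at this position therefore depends on the substituents on a six-membered ring as well as on the ring itself, and compound 3 lies between compound 1 and compound 2, with its steps to both beyond the scatter.

Going by these compounds, it remains open where an unsubstituted phenyl, or a phenyl carrying an amine or a carboxylic acid, would fall in this order. No measurement available here accounts for the order of the three compounds.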